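Working notes: methoxy in place of chloro in the series

The compounds below may be only part of what the source reports. "The series", "measured", "known", "first", "only" and "open" are said of these compounds alone.

Measured so far in an in vitro ADME assay on microsomes from liver (Homo sapiens) for pharmacokinetics, read by LC-MS, with a stated time of 10 min, tested at 1 uM; on this read-out lower numbers stand for slow clearance and higher numbers for fast clearance:
Compound 1 `COc1ccc(NC(=O)[C@H]2CN(C)C[C@@H]2c2ccc(/C=C/C(=O)Nc3ccccc3N)cc2)cc1` gives 14 mL/min/kg as clearance
Compound 2 `CN1C[C@H](C(=O)Nc2cccc(Cl)c2)[C@@H](c2ccc(/C=C/C(=O)Nc3ccccc3N)cc2)C1` gives 7 mL/min/kg as clearance

Among the compounds with values here, compound 2 stands within the scatter of compound 1, the only other measured compound, so the two numbers are not separated. Compound 3 `COc1cccc(NC(=O)[C@H]2CN(C)C[C@@H]2c2ccc(/C=C/C(=O)Nc3ccccc3N)cc2)c1` has not yet been measured. The change from compound 2 is methoxy in place of chloro on an aromatic carbon, which in words is methoxy in place of chloro on an aromatic carbon, meta to a large group.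

Within the data shown here, one measured step bears on this: a 2.0-fold lower number from compound 1 to compound 2 (0.30 log units; within the scatter), with 3-chlorophenyl in place of 4-methoxyphenyl on an amide-type nitrogen. It bears only indirectly, since compound 1 carries 4-methoxyphenyl and compound 3 carries 3-methoxyphenyl. Among the measured compounds shown here, no measured pair compares methoxy and chloro at the same place. Nothing beyond the scatter is therefore expected in this assay, with at most a small drift toward the number of compound 1 (14 mL/min/kg). The expected change is a 1.6-fold higher number from compound 2 to compound 3 (0.20 log units; within the scatter) and is not expected to leave the scatter. For compound 3 the estimated clearance is 11 mL/min/kg (expected range 5 mL/min/kg to 22 mL/min/kg).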

Compound 3, clearance: 14 mL/min/kg
Estimate against measurement, compound 3: 1.3-fold (0.10 log units) below; low and high end bracket the measured number.
By their numbers in this assay, from the lowest: compounds 2, 1 and 3 (each within the scatter of the next).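

In this assay, within the data shown here, methoxy in place of chloro on an aromatic carbon, meta to a large group, gives a 2.0-fold higher number from compound 2 to compound 3 (0.30 log units; within the scatter) and so provides the first direct comparison of the two groups at one place. The earlier pair of compounds did not give this comparison. That pair also differed in where the substituent sat. The step with 3-methoxyphenyl in place of 4-methoxyphenyl gives no change at the digits printed from compound 1 to compound 3 (within the scatter) and is the first to isolate the placing of methoxy on this ring, so neither the exchange of chloro for methoxy nor this shift of methoxy separates the numbers among the three compounds shown. No measurement offered alongside these clearance numbers accounts for them.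

Open, as far as these compounds go, is whether a group of another kind at this place, such as an amine, a carboxylic acid or a longer chain like propoxy, would give a step beyond the scatter. Also open is how chloro compares with methoxy in the place held by the methoxy of 4-methoxyphenyl, as no pair of compounds shown makes that comparison.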